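This account rests on a few compounds, and the source may have more. Where it says the series, first, only, none or still open, it means among the compounds named here.

Going by the values given here, compound 2 `Oc1nc2nonc2nc1Nc1cccc(F)c1` gives 31200 nM in an assay on mitochondria from L6 cells (Rattus norvegicus) for activation, with a stated time of 90 min (a higher number here means that more compound is needed for the effect, a lower number that less compound is needed), the lowest of the two numbers so far; compound 1 `COc1cccc(Nc2nc3nonc3nc2O)c1` gives 75400 nM, and the step of a 2.4-fold lower number from compound 1 to compound 2 (0.38 log units; beyond the scatter) is modest. Compound 3 `CC(C)(C)c1cccc(Nc2nc3nonc3nc2O)c1` is unmeasured and differs from compound 2 by tert-butyl in place of fluoro on an aromatic carbon. Among the compounds with values here, no measured step puts tert-butyl in place of fluoro; the only step known, a 2.4-fold lower number from compound 1 to compound 2 (0.38 log units; beyond the scatter), concerns methoxy and fluoro, so it bears on this change only loosely. A small rise in the number, near the scatter, is therefore expected, a 1.3-fold higher number from compound 2 to compound 3 (0.13 log units; within the scatter). Compound 3 is estimated at 42000 nM, in a range from 12000 nM to 150000 nM.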

Compound 3, half-maximal effective concentration: 2200 nM
Compound 3: middle estimate off by 19-fold (1.28 log units), on the high side; the measured number lies below the stated range.
By their numbers in this assay, from the lowest: compound 3; then compound 2; then compound 1.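

At this aromatic carbon the number moves far more than the methoxy and fluoro pair alone suggested: in this assay tert-butyl in place of fluoro gives a 14-fold lower number from compound 2 to compound 3 (1.15 log units; beyond the scatter), and tert-butyl in place of methoxy gives a 34-fold lower number from compound 1 to compound 3 (1.53 log units; beyond the scatter). Both steps are large, where the earlier step was modest. Nothing given here bears on the reason for these steps.

It remains open whether the large step is particular to tert-butyl, since the compounds shown do not say how an isopropyl group, a trifluoromethyl group or a carboxylic acid would read at this carbon. They also do not say whether tert-butyl on another carbon of the ring would give a similar step.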